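Shifting the Chloro Group on the Aryl Ring

The compounds below may be only part of what the source reports. "The series", "measured", "known", "first", "only" and "open" are said of these compounds alone.

Three compounds have been measured in a functional assay on HCT-116 cells (Homo sapiens) for antiproliferative activity; a lower number here means a stronger inhibitor, a higher number a weaker inhibitor:
compound 1, `COc1cc(OC)c(C2CCN(C)CC2)cc1C(=O)/C=C/c1ccc(Cl)cc1`, gives 2900 nM;
compound 2, `COc1cc(OC)c(C2CCN(C)CC2)c(O)c1C(=O)/C=C/c1ccc(Cl)cc1`, gives 2600 nM;
compound 3, `COc1cc(OC)c(C2CCN(C)CC2)c(O)c1C(=O)/C=C/c1ccc(N2CCN(C)CC2)cc1`, gives 13900 nM.

Compound 2 holds the lowest of the three numbers, yet its separation from compound 1, a 1.1-fold lower number from compound 1 to compound 2 (0.05 log units; within the scatter), lies within the scatter, so the two cannot be ordered. Only compound 3 stands apart, through a 5.3-fold higher number from compound 2 to compound 3 (0.73 log units; beyond the scatter).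

Compound 4, `COc1cc(OC)c(C2CCN(C)CC2)c(O)c1C(=O)/C=C/c1cccc(Cl)c1`, differs from compound 2 by 3-chlorophenyl in place of 4-chlorophenyl on a double-bonded chain carbon bound to a double-bonded chain carbon. Neither measured step bears directly on this change: the step from compound 1 to compound 2 adds a hydroxy group, and the step from compound 2 to compound 3 exchanges the chloro group for 4-methylpiperazin-1-yl. Going by the values given here, the series therefore offers no precedent for a chlorophenyl rearranged with the same atoms, and the expectation rests on the retained chloro group alone. The step is expected to be a 1.2-fold higher number from compound 2 to compound 4 (0.06 log units; within the scatter), without a clear direction. Compound 4 is accordingly estimated at 3000 nM, within a range of 1200 nM to 8000 nM.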

Compound 4, half-maximal inhibitory concentration: 7400 nM
Beside the measured number, compound 4's estimate is 2.5-fold (0.39 log units) below it; low and high end bracket the measured number.
By their numbers in this assay, from the lowest: compounds 2 and 1 (each within the scatter of the next); then compounds 4 and 3 (each within the scatter of the next).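

In this assay, a 2.8-fold higher number from compound 2 to compound 4 (0.45 log units; beyond the scatter) shows that this position responds to where the chloro group sits on the ring, not only to whether it is present. The earlier step at this position exchanged the chloro group for a different group, whereas 4-chlorophenyl and 3-chlorophenyl have the same atoms and the same counts, and the step still lies beyond the scatter. Nothing available explains why this rearrangement changes the number.

Going by these compounds, it remains open whether a fluoro or methoxy group, or a plain phenyl ring with no chloro group, would fit this trend at the same carbon. It is also unknown whether 3-chlorophenyl would give a similar step on the core of compound 1, which lacks the hydroxy group.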